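The compounds below may be only part of what the source reports. "The series", "measured", "known", "first", "only" and "open" are said of these compounds alone.

In an ADME assay on Raji cells (Homo sapiens) for cytotoxicity, with a stated time of 72 h (on this read-out higher numbers stand for an effect only at larger amounts of compound and lower numbers for an effect already at smaller amounts), compound 1 `Cc1cc(NC(=O)Nc2ccc(C(F)(F)F)cc2)c2ccccc2n1` gives 23000 nM as an exact number. Compound 2 `Cc1cc(NC(=O)Nc2ccc(C(N)=O)cc2)c2ccccc2n1` gives > 25000 nM and this is a limit, not a number. Compound 3 `Cc1cc(NC(=O)Nc2cccnc2)c2ccccc2n1` gives > 25000 nM and this too is a limit. Compound 3 therefore stands at the limit of > 25000 nM in this assay, at which 2 of the 3 values shown sit, and has no exact position of its own.

Compound 4 `Cc1cc(NC(=O)Nc2ccc(Cl)cc2)c2ccccc2n1` has not yet been measured. It differs from compound 3 by having 4-chlorophenyl in place of pyridin-3-yl on an amide-type nitrogen.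

Among the compounds with values here, no measured step makes this same exchange. Within the data shown here, the one measured step in the set (an at least 1.0-fold higher number from compound 1 to compound 2 (0.03 log units; that floor lies within the scatter)) puts carbamoyl in place of trifluoromethyl on an aromatic carbon. It is only a floor that lies within the scatter, so it shows no real change and offers little guidance on size or direction. With so little to go on, no step beyond the scatter is expected, in either direction. Among the measured compounds shown here, compound 4 is expected in the same region as compound 1 because compound 1 gives 23000 nM as the only exact number available.

The step this implies is expected to be small (an at least 1.2-fold lower number from compound 3 to compound 4 (0.09 log units; that floor lies within the scatter)). For compound 4 the estimated value is 20000 nM with an expected range from 10000 nM to 30000 nM in this assay.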

Compound 4, half-maximal effective concentration: > 25000 nM
Compound 4: only a limit was reported; the forecaster's own chance of this, stated with the estimate: 40%; middle value at least 1.2-fold (0.09 log units) from the limit.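

In this assay compound 4 gives only a limit, not a number, and it joins compound 2 and compound 3 there: the limit of > 25000 nM in this assay, at which 3 of the 4 values shown sit. Both compound 3 and compound 4 are limits, so the step between them cannot be read, and the same holds for the step between compound 2 and compound 4; 4-chlorophenyl in place of pyridin-3-yl on the amide-type nitrogen therefore shows no measurable change. Chloro in place of trifluoromethyl on the aromatic carbon gives an at least 1.0-fold higher number from compound 1 to compound 4 (0.03 log units; that floor lies within the scatter), so this exchange, measured against the only compound with an exact number, shows no real change either.

The compounds shown leave open whether any change at this position can bring the number clearly down, since none of the steps that can be read goes beyond the scatter. From the compounds shown here alone, what an amine or a carboxylic acid in place of chloro, or a longer alkyl chain in place of the aromatic ring, would give in this assay also remains open.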